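The compounds below may be only part of what the source reports. "The series", "measured", "known", "first", "only" and "open" are said of these compounds alone.

Three compounds share one core and were measured in an assay for inhibition of sodium- and chloride-dependent glycine transporter 1 (Homo sapiens); a higher number here means that more compound is needed for the effect, a lower number that less compound is needed. Compound 1 `O=C(CCc1ccccc1)NCC(=O)NC(c1ccccc1)c1ccc(Cl)cc1` gives 4790 nM. Among the compounds with values here, compound 2 `O=C(CNC(=O)c1ccccc1)NC(c1ccccc1)c1ccc(Cl)cc1` gives 390 nM, and the step of a 12-fold lower number from compound 1 to compound 2 (1.09 log units; beyond the scatter) is the only single change measured here. Compound 3 `Cc1cccc(C(NC(=O)CNC(=O)c2ccc(F)cc2)c2ccccc2)c1` gives 56 nM, the lowest of the three numbers; its gap to compound 2 and its gap to compound 1 both lie beyond the scatter.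

Compound 4 `O=C(CNC(=O)c1ccc(F)cc1)NC(c1ccccc1)c1nccs1` differs from compound 3 in one place: 1,3-thiazol-2-yl in place of 3-methylphenyl on a saturated chain carbon bound to an amide-type nitrogen and an aromatic carbon. Within the data shown here, no measured step touches that position; the step from compound 1 to compound 2 concerns a different part of the molecule, a group on a carbonyl carbon, so it says nothing about an exchange of one aromatic ring for another on the chain carbon. The expectation therefore rests on little, and a moderate step towards a higher number, expressed as a 3.6-fold higher number from compound 3 to compound 4 (0.55 log units; beyond the scatter), is estimated, with a wide range. Compound 4 is expected to give 200 nM, between 40 nM and 1000 nM.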

Compound 4, half-maximal effective concentration: 5050 nM
The estimate for compound 4 lay 25-fold (1.40 log units) below the measured number, and the stated range ends below it.
By their numbers in this assay, from the lowest: compound 3; then compound 2; then compounds 1 and 4 (each within the scatter of the next).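

In this assay, the chain carbon bound to an amide-type nitrogen and an aromatic carbon proves highly sensitive to the ring it carries: 1,3-thiazol-2-yl in place of 3-methylphenyl gives a 90-fold higher number from compound 3 to compound 4 (1.96 log units; beyond the scatter). Within the data shown here, until now, the only single change measured was at a group on a carbonyl carbon, so this is the first direct sign that this second place matters too, and the change here is large. Several features change together, from a six-membered ring of carbon only to a five-membered ring with two hetero atoms, and no measurement available here explains the loss.

The compounds shown leave open whether ring size or the hetero atoms matter more. A thiophen-2-yl or pyridin-2-yl ring on the same carbon could help separate those two features.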